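The compounds below may be only part of what the source reports. "The series", "measured", "known", "first", "only" and "open" are said of these compounds alone.

Measured so far in an ADME assay on L6 cells (Rattus norvegicus) for cytotoxicity; on this read-out higher numbers stand for weaker inhibition and lower numbers for stronger inhibition:
- compound 1 `CN1CCN(CCCC(=O)OC2CC3(N4CCCCC4)CC(c4ccccc4)C2C(c2ccccc2)C3)CC1`: 22300 nM
- compound 2 `O=C(CN1CCCCC1)OC1CC2(N3CCCCC3)CC(c3ccccc3)C1C(c1ccccc1)C2`: 60400 nM

Among the measured compounds shown here, of these two, compound 1 stands lower, at 22300 nM, and no other measured compound lies closer to it than compound 2. The compound still to be measured is compound 3 `CN1CCN(CCCC(=O)OC2CC3(N(C)C)CC(c4ccccc4)C2C(c2ccccc2)C3)CC1`. It differs from compound 1 in one place: dimethylamino in place of piperidin-1-yl on a saturated ring carbon. In short, dimethylamino takes the place of piperidin-1-yl on a saturated ring carbon.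

For the measured compounds named here, no measured step touches that ring carbon. Going by the values given here, the only step available, a 2.7-fold higher number from compound 1 to compound 2 (0.43 log units; beyond the scatter), is modest and was made elsewhere, on a saturated chain carbon bound to a carbonyl carbon. It therefore offers only a rough scale for what a single change does in this assay, and none for direction at the ring carbon. A step no larger than that one is expected, most likely within the scatter, with a slight lean towards a higher number. The expected step is a 1.4-fold higher number from compound 1 to compound 3 (0.16 log units; within the scatter). For compound 3 the estimated value is 32000 nM, with an expected range of 12000 nM to 80000 nM.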

Compound 3, half-maximal inhibitory concentration: 19900 nM
Compound 3: the middle estimate sits 1.6-fold (0.21 log units) above what was measured; measured number inside the range.
By their numbers in this assay, from the lowest: compounds 3 and 1 (each within the scatter of the next); then compound 2.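

In this assay the saturated ring carbon takes dimethylamino in place of piperidin-1-yl with a 1.1-fold lower number from compound 1 to compound 3 (0.05 log units; within the scatter) and thus with no change that can be told from the scatter, although the entering group has 3 heavy atoms and no ring, while the leaving group has 6 heavy atoms and a six-membered non-aromatic ring. The earlier compounds shown here showed only a change on a saturated chain carbon bound to a carbonyl carbon, where a 2.7-fold higher number from compound 1 to compound 2 (0.43 log units; beyond the scatter) lay beyond the scatter, and they gave no reading at all for this ring carbon, which now has one. No measurement at hand bears on why the read-out holds at this position.

The compounds shown leave open whether a morpholin-4-yl group or a primary amine on that ring carbon would also stay within the scatter of compound 1. Among the compounds shown here, they also leave open whether dimethylamino in place of piperidin-1-yl would read the same when the ester side chain is the one carried by compound 2 rather than the one carried by compound 1.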